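A few compounds are considered here, and "the series" means these few. Any claim that something is new, unique, unknown or untested is made for them only; others in the source may bear on it.

Measured compounds:
- compound 1 `CO/N=c1/ccn([C@@H]2O[C@H](COP(=O)(O)OP(=O)(O)OP(=O)(O)OP(=O)(O)O[C@H]3O[C@H](CO)[C@@H](O)[C@H](F)[C@H]3O)[C@@H](O)[C@H]2O)c(=O)[nH]1`: 500 nM
- compound 2 `CC(C)(C)O/N=c1/ccn([C@@H]2O[C@H](COP(=O)(O)OP(=O)(O)OP(=O)(O)O)[C@@H](O)[C@H]2O)c(=O)[nH]1`: 1500 nM

In an in vitro functional assay on 1321-N1 cells for agonist activity at P2Y purinoceptor 2 (Homo sapiens), read by scintillation proximity assay and inositol phosphate accumulation, with a stated time of 30 min (a lower number here means that less compound is needed, a higher number that more compound is needed for the effect), compound 1 gives 500 nM and compound 2 gives 1500 nM. Compound 2 thus stands at the higher of the two numbers, and its gap to compound 1 lies beyond the usual scatter; since the two compounds differ in more than one place, nothing more can be drawn from that pair than the two values themselves.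

Compound 3 `O=c1[nH]/c(=N\OCc2ccccc2)ccn1[C@@H]1O[C@H](COP(=O)(O)OP(=O)(O)OP(=O)(O)O)[C@@H](O)[C@H]1O` is not yet measured. It differs from compound 2 in one place: benzyl in place of tert-butyl on an oxygen. For the measured compounds named here, no measured pair shows this change, so there is no step on record to lean on. With only the tert-butyl-bearing compound 2 as the nearest point, the change of benzyl in place of tert-butyl on an oxygen is expected to move the number by at most a modest amount in the direction of a lower value, a step of a 1.5-fold lower number from compound 2 to compound 3 (0.18 log units; within the scatter), which may well fall within the scatter. Compound 3 is therefore estimated at 1000 nM in this assay, with a likely range from 300 nM to 4000 nM.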

Compound 3, half-maximal effective concentration: 620 nM
Beside the measured number, compound 3's estimate is 1.6-fold (0.21 log units) above it, and the stated range covers the measured number.
By their numbers in this assay, from the lowest: compounds 1 and 3 (each within the scatter of the next); then compound 2.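

In this assay, for the compounds shown here, putting benzyl in place of tert-butyl on an oxygen whose other neighbour is a double-bonded nitrogen gives a 2.4-fold lower number from compound 2 to compound 3 (0.38 log units; beyond the scatter), the first step on record that isolates this position. It shows that the group on this oxygen can affect the number in this assay, and that a group with a six-membered aromatic ring of carbon only, and with more heavy atoms than tert-butyl, is accepted here without the number rising. Nothing measured accounts for the size or direction of this step, so the result stands as an observation without an explanation.

On these data alone, it remains open how other groups on this oxygen would behave, such as a longer chain, a benzyl carrying a methoxy or a chloro substituent on its ring, or a chain ending in an amine or a carboxylic acid. It is also unknown whether the same change would give a similar step in the setting of compound 1, which differs from compound 2 in more than one place.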